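Urea to amide on a pyrazole series against lung carcinoma cells

The source may hold more compounds than are shown below. What is called first, only, known or untested is meant among the compounds shown, and "the series" means these compounds.

Of the compounds shown here, two that share one core have been measured in a functional assay on HOP-62 cells (Homo sapiens) for inhibition, read by sulforhodamine B assay, with a stated time of 48 h, tested at 1 uM; a lower number here means a stronger effect, a higher number a weaker effect of the compound at the concentration tested. Compound 1 `COc1cc(Cl)cc(-c2nn(-c3cccc(NC(=O)Nc4ccc(Cl)c(C(F)(F)F)c4)c3)cc2-c2ccncc2)c1` gives 84% in this assay, and compound 2 `COc1cc(Cl)cc(-c2nn(-c3cccc(NC(=O)Nc4cccc(C(F)(F)F)c4)c3)cc2-c2ccncc2)c1` gives 85%. Among the measured compounds shown here, the only step between measured compounds, a number 1 percentage points higher from compound 1 to compound 2 (within the scatter), shows that hydrogen in place of chloro on an aromatic carbon changed nothing that can be told from the scatter. Compound 2 thus stands at the higher of the two numbers, though its gap to compound 1 lies within the scatter, so neither can be called stronger.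

Compound 3 `COc1cc(Cl)cc(-c2nn(-c3cccc(NC(=O)c4cccc(C(F)(F)F)c4)c3)cc2-c2ccncc2)c1` differs from compound 2 at another place: 3-(trifluoromethyl)phenyl in place of (3-(trifluoromethyl)phenyl)amino on a carbonyl carbon. For the measured compounds named here, no measured step touches the carbonyl carbon, so the single step that exists, from compound 1 to compound 2, bears on this change only loosely, and it was itself small. With both measured compounds sitting close together, the expectation is a step for compound 3 of a number 3 percentage points higher from compound 2 to compound 3 (within the scatter), that is, no change beyond the scatter, and the estimated value for compound 3 in this assay is 88%, with a range from 72% to 100%.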

Compound 3, a percentage reported as activity, at one concentration (the size of the read-out at that concentration, not a potency): 101%
Estimate against measurement, compound 3: 13 percentage points below, outside the stated range (above it).
By their numbers in this assay, from the lowest: compounds 1 and 2 (each within the scatter of the next); then compound 3.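

The carbonyl carbon proves to be a place where a change can be read in this assay, unlike the swap of chloro for hydrogen on an aromatic carbon: putting 3-(trifluoromethyl)phenyl in place of (3-(trifluoromethyl)phenyl)amino gives a number 16 percentage points higher from compound 2 to compound 3 (beyond the scatter) and so a modest loss of effect at the concentration tested. The chlorinated urea points the same way, since 3-(trifluoromethyl)phenyl in place of (4-chloro-3-(trifluoromethyl)phenyl)amino gives a number 17 percentage points higher from compound 1 to compound 3 (beyond the scatter) and thus shows that the amide stands apart from both ureas, which themselves lie within the scatter of each other. Nothing available here accounts for this loss.

The compounds shown leave open whether the effect depends on the amino nitrogen itself or on the urea as a whole, which a methylene group or an oxygen atom in its place on the carbonyl carbon would help to separate. They also leave open whether 4-chloro-3-(trifluoromethyl)phenyl on the carbonyl carbon would behave as 3-(trifluoromethyl)phenyl does, or whether a chloro group counts for more in the amide than it does in the urea.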